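Removing a fluoro group from compound 3: what to expect

The source may hold more compounds than are shown below. What is called first, only, known or untested is meant among the compounds shown, and "the series" means these compounds.

Measured compounds:
compound 1, `Fc1ccc(-c2ccc(Cn3ccnc3)cc2)cn1`: 13%
compound 2, `c1cncc(-c2ccc(Cn3ccnc3)cc2)c1`: 14%
compound 3, `Fc1ccc(-c2csc(Cn3ccnc3)c2)cc1F`: 25%

All three were tested in an assay for inhibition of steroid 17-alpha-hydroxylase/17,20 lyase (Homo sapiens), using NADPH, tested at 2 uM; a lower number here means a weaker effect, a higher number a stronger effect of the compound at the concentration tested. Compound 1 and compound 2 share a core and differ by hydrogen in place of fluoro on an aromatic carbon; that change gave a number 1 percentage points higher from compound 1 to compound 2 (within the scatter). Compound 3 has the highest number of the three, with compound 2 nearest and compound 1 furthest, both beyond the scatter. The difference between the core of compound 3 and the core of compound 1 is not broken down here.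

Compound 4, `Fc1ccc(-c2csc(Cn3ccnc3)c2)cc1`, is not yet measured. It differs from compound 3 by hydrogen in place of fluoro on an aromatic carbon. This is the same kind of change as from compound 1 to compound 2, but its surroundings differ: in compound 1 the place is on a six-membered aromatic ring with 1 nitrogen, next to the ring nitrogen, para to a large group, whereas in compound 3 it is on a six-membered aromatic ring of carbon only, ortho to a fluoro group, meta to a large group.

Because the earlier step was a number 1 percentage points higher from compound 1 to compound 2 (within the scatter), a similarly small step is expected for compound 4, namely a number 3 percentage points lower from compound 3 to compound 4 (within the scatter). Compound 4 is therefore estimated at 22%, likely between 8% and 36%.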

Compound 4, a percentage reported as inhibition, at one concentration (the size of the read-out at that concentration, not a potency): 20%
The estimate for compound 4 lay 2 percentage points above the measured number; the range from low to high includes it.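

Replacing fluoro by hydrogen on an aromatic carbon gave a number 5 percentage points lower from compound 3 to compound 4 (within the scatter) in this assay. Set beside the earlier case, the two steps do not differ from one another: the same change on two cores in this assay, a number 1 percentage points higher (within the scatter) from compound 1 to compound 2 and a number 5 percentage points lower (within the scatter) from compound 3 to compound 4, 6 percentage points apart, within the scatter of two such steps. The change thus stayed within the scatter on both cores and in both surroundings, but this does not show that the fluoro group is without any effect, as small real differences cannot be told from scatter, and two pairs say nothing about other cores or other places on the ring.

The compounds shown leave open whether a larger group on this aromatic carbon, such as methoxy, a nitrile or an amine, would move the read-out beyond the scatter. They also leave open what hydrogen in place of the fluoro group still present in compound 4 would give, and how the change behaves on a core with a much higher number at the tested concentration.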